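Swapping a methoxy for a chloro on a weak sulfone

The source may report more compounds than this note shows. Statements on the series, on what has been measured and on what is new or still open speak of the compounds shown alone.

Three compounds with a shared core were tested in a functional assay on H157 cells (Homo sapiens) for antiproliferative activity, read by trypan blue exclusion; on this read-out lower numbers stand for stronger inhibition and higher numbers for weaker inhibition. Compound 1, `COc1ccc(/C=C/S(=O)(=O)Cc2ccc(OC)cc2)cc1`, gives > 20000 nM in this assay, which is a limit of the assay rather than a number. Compound 2, `COc1cc(OC)c(/C=C/S(=O)(=O)Cc2cc(OC)c(OC)c(OC)c2)c(OC)c1`, carries extra methoxy groups, and in this assay compound 2 gives > 20000 nM, again a limit and not a number. Compound 3, `COc1cc(OC)c(/C=C/S(=O)(=O)Cc2ccc(Cl)cc2)c(OC)c1`, has a chloro on one ring, and in this assay compound 3 gives 15000 nM. Compound 1 thus stands at the limit of > 20000 nM in this assay, at which 2 of the 3 values shown sit, without a number of its own.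

Compound 4, `COc1ccc(CS(=O)(=O)/C=C/c2ccc(Cl)cc2)cc1`, differs from compound 1 by chloro in place of methoxy on an aromatic carbon. For the measured compounds named here, no measured pair of compounds covers this change on this side of the core, so the expectation rests on the weak readings of all three. The change is expected to give a number no higher from compound 1 to compound 4 (the limit leaves the size open), no clear step beyond the scatter. Compound 4 is therefore estimated at 20000 nM, within 8000 nM to 50000 nM, with a real chance that this assay again reports only a limit.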

Compound 4, half-maximal inhibitory concentration: 3500 nM
Compound 4: the middle estimate sits 5.7-fold (0.76 log units) above what was measured; the whole stated range lies above it.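

For the compounds shown here, until this result, no two compounds differed in only one place, so nothing showed what a single group could do in this assay. Chloro in place of methoxy on an aromatic carbon, para to a large group, gives an at least 5.7-fold lower number from compound 1 to compound 4 (0.75 log units; beyond the scatter), so a change at this one position can move the read-out beyond the scatter. The size of this step is only a lower bound, since compound 1 has a limit rather than a number of its own: the limit of > 20000 nM in this assay, at which 2 of the 4 values shown sit.

A single step cannot separate what chloro adds from what the loss of methoxy removes. The compounds shown also leave open how a fluoro, a methyl or an amine at this position would read in this assay, and what a change to the remaining methoxy of compound 4 would do.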